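A few compounds are considered here, and "the series" means these few. Any claim that something is new, unique, unknown or untested is made for them only; others in the source may bear on it.

Measured so far:
Compound 1 `C=CC1=C(C(=O)NCc2ccccc2)C(c2ccc(OC)cc2)OC1` gives > 100000 nM in a functional assay on A549 cells (Homo sapiens) for cytotoxicity, read by MTT assay, with a stated time of 24 h; on this read-out higher numbers stand for weaker inhibition and lower numbers for stronger inhibition; this value is a limit of the assay, not a number.
Compound 2 `C=CC1=C(C(=O)O)C(c2ccc(F)cc2)OC1` gives > 100000 nM in this assay, again a limit.
Compound 3 `C=CC1=C(C(=O)Nc2ccccc2)C(c2ccc(Cl)c(Cl)c2)OC1` gives > 100000 nM in this assay, also a limit.

Compound 2 stands exactly where the other two measured compounds stand: at a limit, with no number of its own, as the limit of > 100000 nM in this assay, at which 3 of the 3 values shown sit, records. Going by the values given here, on these values no compound can be set apart from another, and no step between measured compounds can be stated.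

Compound 4 `C=CC1=C(C(=O)Nc2cccc(C)c2)C(c2ccc(F)cc2)OC1` has not yet been measured. It differs from compound 2 in one place: (3-methylphenyl)amino in place of hydroxy on a carbonyl carbon. Since every measured compound, whatever sits on the carbonyl carbon, rests at the limit, the expectation for the step from compound 2 to compound 4 is none beyond the scatter, namely a number no higher from compound 2 to compound 4 (the limit leaves the size open). Compound 4 is therefore expected at 100000 nM, within a range from 40000 nM to 300000 nM, and most probably reported once more only as a limit.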

Compound 4, half-maximal inhibitory concentration: > 100000 nM
Compound 4: only a limit was reported; the forecaster's own chance of this, stated with the estimate: 85%; the middle value sits exactly at the limit.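

Going by these compounds alone, compound 2 and compound 4 rest at the same limit, not at numbers, so no step between them can be read: the limit of > 100000 nM in this assay, at which 4 of the 4 values shown sit.

The compounds shown leave open whether any of them gives a measurable number in this assay at all.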